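A Smaller Group on the Aromatic Carbon of Compound 2

This account rests on a few compounds, and the source may have more. Where it says the series, first, only, none or still open, it means among the compounds named here.

Compound 1 `CCCCCSc1nc(N)c2nc(O)n(Cc3ccccc3)c2n1`: 10 uM
Compound 2 `CCCC[S+]([O-])c1nc(N)c2nc(O)n(Cc3ccccc3)c2n1`: 0.01 uM

For the measured compounds named here, in a functional assay (spleen, spleen) for activation, with Mus musculus as the target (on this read-out higher numbers stand for an effect only at larger amounts of compound and lower numbers for an effect already at smaller amounts), compound 2 holds the lowest of the two numbers, and compound 1 is the only neighbour. Going by the values given here, the single known step is a 1000-fold lower number from compound 1 to compound 2 (3.00 log units; beyond the scatter), a change of the group on this same aromatic carbon. Compound 3 `CCOc1nc(N)c2nc(O)n(Cc3ccccc3)c2n1` differs from compound 2 by a group of 3 heavy atoms (2 carbon, 1 oxygen; no ring) in place of a group of 6 heavy atoms (4 carbon, 1 oxygen, 1 sulfur; no ring), on an aromatic carbon. Among the compounds with values here, no measured step covers this exchange, but the one step known shows that this position can move the read-out strongly, so a large step upward is expected, a 100-fold higher number from compound 2 to compound 3 (2.00 log units; beyond the scatter). Compound 3 is therefore estimated at 1 uM, within 0.05 uM to 20 uM.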

Compound 3, minimum effective concentration: 0.1 uM
Estimate against measurement, compound 3: 10-fold (1.00 log units) above; the range from low to high includes it.
By their numbers in this assay, from the lowest: compound 2; then compound 3; then compound 1.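

In this assay, the small ethoxy group on this aromatic carbon gives a far lower number than the pentylsulfanyl group (a 100-fold lower number from compound 1 to compound 3 (2.00 log units; beyond the scatter)). A low number here therefore does not depend on the sulfur-containing group of compound 2, although compound 2 still keeps the lowest number (a 10-fold higher number from compound 2 to compound 3 (1.00 log units; beyond the scatter)). Nothing available here explains these differences. Still open, going by these compounds, is where an amine or a longer chain such as butoxy on this carbon would fall. Butylsulfanyl is open too: compound 1 and compound 2 differ in both chain length and the oxygen on sulfur, and this group would separate the two.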